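Replacing a silicon-bearing group with hydrogen in compound 2

The source may report more compounds than this note shows. Statements on the series, on what has been measured and on what is new or still open speak of the compounds shown alone.

Compound 1 `CC(C)(C)[Si](C)(C)O[C@@H]1CCCO[C@@H]1/C=C\C(=O)OCc1ccccc1`: 20000 nM
Compound 2 `CC(C)(C)[Si](C)(C)O[C@@H]1CCCO[C@@H]1CC(=O)OCc1ccccc1`: 19000 nM

Both values come from a functional assay on WiDr cells (Homo sapiens) for antiproliferative activity, read by sulforhodamine B assay, with a stated time of 48 h; a lower number here means a stronger inhibitor of growth, a higher number a weaker inhibitor of growth. Compound 2 stands at 19000 nM, and compound 1 at 20000 nM. These two numbers lie within the usual scatter of each other, so neither compound can be ranked above the other.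

The next compound is compound 3 `O=C(C[C@H]1OCCC[C@H]1O)OCc1ccccc1`, which differs from compound 2 by a single change: a hydrogen atom in place of a group of 7 heavy atoms (6 carbon, 1 silicon; no ring), on an oxygen on a saturated carbon. A hydrogen atom takes the place of the group, on an oxygen on a saturated carbon. Within the data shown here, no measured pair of compounds shows what this change does in this assay, so any expectation is tentative. A weaker inhibitor of growth is expected, with a higher number and a step beyond the scatter. The expected step is a 3.2-fold higher number from compound 2 to compound 3 (0.50 log units; beyond the scatter). The estimate for compound 3 is 60000 nM, with an estimated range from 25000 nM to 100000 nM.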

Compound 3, concentration for 50% growth inhibition: > 100000 nM
Compound 3: a limit, no number; the forecaster's own chance of this, stated with the estimate: 35%; middle value at least 1.6-fold (0.22 log units) from the limit.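

In this assay, compound 3 gives > 100000 nM, which is a limit of the assay and not a number. Compounds 1 and 2 both carry the silicon-bearing group, so they said nothing about this oxygen on a saturated carbon, whereas putting a hydrogen atom in place of that group of 7 heavy atoms gives an at least 5.2-fold higher number from compound 2 to compound 3 (0.72 log units; beyond the scatter). The group therefore cannot be exchanged for hydrogen here without a loss of growth inhibition, but the full size of that loss stays unknown because only a bound is available: the limit of > 100000 nM in this assay, at which 1 of the 3 values shown sits.

The compounds shown leave open whether a methyl group, an acetyl group or a longer carbon chain on this oxygen would keep the level of compound 2. They also leave open whether the same change on compound 1 would give a similar step.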